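Swapping the aryl group on the ring amide nitrogen

This account rests on a few compounds, and the source may have more. Where it says the series, first, only, none or still open, it means among the compounds named here.

Compound 2 `Cc1ccc(N2CC(c3nc(-c4cccc(Cl)c4)no3)CC2=O)cc1` carries 4-methylphenyl on an amide-type nitrogen in a ring. Among the compounds with values here, in an in vitro functional assay on HEK293-A cells for positive allosteric modulation of metabotropic glutamate receptor 5 (Homo sapiens), read by FLIPR and calcium flux (on this read-out lower numbers stand for an effect already at smaller amounts and higher numbers for an effect only at larger amounts of compound), compound 2 gives 630 nM, which is the only true number among the two compounds measured so far. Compound 1 `Cc1cccc(N2CC(c3nc(-c4cccc(Cl)c4)no3)CC2=O)c1` differs only in carrying 3-methylphenyl at that position. In this assay compound 1 is reported as > 10000 nM, a limit of the assay rather than a measured number, as noted in the limit of > 10000 nM in this assay, at which 1 of the 2 values shown sits. Within the data shown here, the single measured step, an at least 15-fold lower number from compound 1 to compound 2 (1.20 log units; beyond the scatter), shows that where the methyl sits on that phenyl ring matters greatly.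

Compound 3 `O=C1CC(c2nc(-c3cccc(Cl)c3)no2)CN1c1cccc(Cl)c1` changes the same phenyl ring again: 3-chlorophenyl in place of 4-methylphenyl on an amide-type nitrogen in a ring. Among the measured compounds shown here, the substituent thus returns to the 3-position that in compound 1 coincided with the limit, though chlorine replaces methyl, which no measured step covers. A large step back toward weaker activity is therefore expected in this assay, estimated as a 9.5-fold higher number from compound 2 to compound 3 (0.98 log units; beyond the scatter). Compound 3 is expected to give about 6000 nM in this assay, within a range from 1500 nM to 25000 nM.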

Compound 3, half-maximal effective concentration: > 10000 nM
Compound 3: only a limit was reported; the forecaster's own chance of this, stated with the estimate: 45%; middle value at least 1.6-fold (0.22 log units) away from the limit.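

In this assay, putting 3-chlorophenyl in place of 4-methylphenyl on the amide-type nitrogen gives an at least 15-fold higher number from compound 2 to compound 3 (1.20 log units; beyond the scatter), a large loss, although this single swap changes both the substituent and where it sits on the phenyl ring. Compound 3 is reported as > 10000 nM, which is a limit of the assay and not a number. The earlier loss is therefore not confined to a methyl group, as compound 1 with 3-methylphenyl and compound 3 with 3-chlorophenyl both end at that limit, leaving compound 2 with 4-methylphenyl as the only one with a true number: the limit of > 10000 nM in this assay, at which 2 of the 3 values shown sit.

The step between compound 1 and compound 3 cannot be read with both ends at a limit, so 3-methylphenyl and 3-chlorophenyl cannot be ranked against each other. Still open, on these data alone, is how 4-chlorophenyl, 4-methoxyphenyl or plain phenyl would behave on this nitrogen, which would help separate the effect of where the substituent sits from the effect of which substituent it is.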